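Aryl ketone swap in trimethoxyphenyl pyrazole enones

This account rests on a few compounds, and the source may have more. Where it says the series, first, only, none or still open, it means among the compounds named here.

Measured so far:
compound 1 `COc1cc(-c2cc(/C=C/C(=O)c3ccc(N)cc3)[nH]n2)cc(OC)c1OC` — 1%
compound 2 `COc1ccc(C(=O)/C=C/c2cc(-c3cc(OC)c(OC)c(OC)c3)n[nH]2)cc1` — -47%

In a functional assay on IGROV-1 cells (Homo sapiens) for cytotoxicity, read by sulforhodamine B assay, with a stated time of 48 h, tested at 10 uM (on this read-out higher numbers stand for a weaker effect at the one concentration tested and lower numbers for a stronger effect), compound 1 gives 1%, and compound 2 gives -47%. For the measured compounds named here, the single measured step, a number 48 percentage points lower from compound 1 to compound 2 (beyond the scatter), is the only comparison available, and it sets compound 2 as the lower of the two numbers, with compound 1 as its nearest neighbour.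

The next compound, compound 3 `COc1cc(-c2cc(/C=C/C(=O)c3ccc(F)c(F)c3)[nH]n2)cc(OC)c1OC`, differs from compound 2 in one place: 3,4-difluorophenyl in place of 4-methoxyphenyl on a carbonyl carbon. This change sits on the carbonyl carbon, the same end of the molecule as the amino-to-methoxy step between compound 1 and compound 2, but the groups involved are different, so that step bears on it only loosely. It shows that a change on this ring can move this assay by a large amount, without fixing the direction for the present swap. A step of modest size in either direction, or none beyond the scatter, is therefore plausible for compound 3; the expected step is a number 17 percentage points higher from compound 2 to compound 3 (beyond the scatter), and compound 3 is estimated at -30%, in the range -80% to 20%.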

Compound 3, a percentage reported as activity, at one concentration (the size of the read-out at that concentration, not a potency): 14%
For compound 3 the middle estimate is 44 percentage points below the measured one, within the range that was stated.
By their numbers in this assay, from the lowest: compound 2; then compound 1; then compound 3.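

Replacing 4-methoxyphenyl with 3,4-difluorophenyl on the carbonyl carbon gives a number 61 percentage points higher from compound 2 to compound 3 (beyond the scatter) in this assay, so this position is sensitive to more than the amino-to-methoxy change seen earlier. The second comparison, a number 13 percentage points higher from compound 1 to compound 3 (beyond the scatter) in the same read-out, places the 3,4-difluorophenyl group on the weaker side of the 4-aminophenyl group, leaving 4-methoxyphenyl as the only one of the three aryl groups with a strong effect at the single concentration tested. No evidence is available on the origin of either step.

For the compounds shown here, with only three aryl groups at this position, it remains open whether the strong effect is specific to the methoxy group or would persist with an ethoxy or hydroxy group in its place, and whether a single fluorine, as in 4-fluorophenyl, would behave like the 3,4-difluorophenyl group. These single-concentration readings also leave open how the three compounds would compare at other concentrations, and whether the same aryl preference would hold with a different group in place of the trimethoxyphenyl ring.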